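Swapping Hydroxymethyl for Isopropyl on the Amide Side Chain

The compounds below may be only part of what the source reports. "The series", "measured", "known", "first", "only" and "open" are said of these compounds alone.

Two compounds have been measured in a functional assay on HCT-8 cells (Homo sapiens) for cytotoxicity, read by MTT assay, with a stated time of 24 h; on this read-out higher numbers stand for weaker inhibition and lower numbers for stronger inhibition:
compound 1 `CC[C@H](C)[C@@H](NC(=O)Cn1cc(C2=C(c3c[nH]c4ccccc34)C(=O)N(C)C2=O)c2ccccc21)C(=O)OC` — in this assay compound 1 gives > 100000 nM, which is a limit of the assay and not a number.
compound 2 `COC(=O)[C@@H](CO)NC(=O)Cn1cc(C2=C(c3c[nH]c4ccccc34)C(=O)N(C)C2=O)c2ccccc21` — in this assay compound 2 gives 22900 nM.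

For the measured compounds named here, compound 2 is therefore the only compound with a definite number; the one other value is a limit. Going by the values given here, the single measured step, an at least 4.3-fold lower number from compound 1 to compound 2 (0.64 log units; beyond the scatter), moves toward the stronger side, but its size is known only as a bound because compound 1 sits at the limit of > 100000 nM in this assay, at which 1 of the 2 values shown sits.

Compound 3 `COC(=O)[C@H](NC(=O)Cn1cc(C2=C(c3c[nH]c4ccccc34)C(=O)N(C)C2=O)c2ccccc21)C(C)C` is not yet measured. Compared with compound 2 it carries isopropyl in place of hydroxymethyl on a saturated chain carbon bound to an amide-type nitrogen and a carbonyl carbon. This is close to the reverse of the measured step: the hydroxymethyl that entered there now leaves, and isopropyl rather than sec-butyl takes its place. The expectation in this assay is therefore a step toward higher numbers, of roughly the size seen before, quite possibly ending at a limit again. The estimated step is a 3.1-fold higher number from compound 2 to compound 3 (0.49 log units; beyond the scatter). For compound 3 the estimated value is 70000 nM, with a range from 25000 nM to 200000 nM.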

Compound 3, half-maximal inhibitory concentration: 25800 nM
For compound 3 the middle estimate is 2.7-fold (0.43 log units) above the measured one; low and high end bracket the measured number.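

In this assay, putting isopropyl in place of hydroxymethyl on this saturated chain carbon gives a 1.1-fold higher number from compound 2 to compound 3 (0.05 log units; within the scatter), so a side chain with no hydrogen-bond donor or acceptor reads the same as one that has both, and the earlier step cannot be credited to hydroxymethyl alone. The change that now stands out is much smaller than it first seemed: sec-butyl and isopropyl differ only by hydrogen in place of methyl on a saturated chain carbon, three bonds along the chain from an amide-type nitrogen and a carbonyl carbon, and that exchange gives an at least 3.8-fold lower number from compound 1 to compound 3 (0.58 log units; beyond the scatter). The true size of this step stays unknown because compound 1 has a limit of the assay and not a number: the limit of > 100000 nM in this assay, at which 1 of the 3 values shown sits.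

What the compounds shown leave open is whether the number can go much lower at this position, since compound 2 and compound 3 both remain in the same high range. A side chain carrying an amine or a carboxylic acid, or a benzyl group in place of these small chains, would test whether anything here moves the number further.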